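Chloro to trifluoromethyl on two pyrazole chalcone cores

The source may hold more compounds than are shown below. What is called first, only, known or untested is meant among the compounds shown, and "the series" means these compounds.

Compound 1 `O=C(/C=C\Nc1ccc(Cl)cc1)c1cn(-c2ccccc2)nc1-c1ccccc1` carries a chloro group on the aniline ring. In an ADME assay on HaCaT cells (Homo sapiens) for antiproliferative activity, read by MTT assay, with a stated time of 48 h (on this read-out lower numbers stand for stronger inhibition and higher numbers for weaker inhibition), compound 1 gives 28400 nM. Compound 2 `O=C(/C=C\Nc1ccc(C(F)(F)F)cc1)c1cn(-c2ccccc2)nc1-c1ccccc1` differs from compound 1 by trifluoromethyl in place of chloro on an aromatic carbon. For compound 2 this assay returns only a limit, > 50000 nM, and no number. The step is an at least 1.7-fold higher number from compound 1 to compound 2 (0.24 log units; that floor lies within the scatter); one of the three values sits at the limit of > 50000 nM in this assay, at which 1 of the 3 values shown sits. Compound 3 `COc1ccc(-c2nn(-c3ccccc3)cc2C(=O)/C=C\Nc2ccc(Cl)cc2)cc1` differs from compound 1 by methoxy in place of hydrogen on an aromatic carbon, and in this assay compound 3 gives 20900 nM, a step of a 1.4-fold lower number from compound 1 to compound 3 (0.13 log units; within the scatter).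

Compound 4 `COc1ccc(-c2nn(-c3ccccc3)cc2C(=O)/C=C\Nc2ccc(C(F)(F)F)cc2)cc1` is not yet measured. It differs from compound 3 by trifluoromethyl in place of chloro on an aromatic carbon, the same change as that from compound 1 to compound 2, at the same place. For the measured compounds named here, the only measured instance of this change runs to a limit, so its true size is unknown, but the direction is toward a weaker result. For compound 4 the expected step is a 2.2-fold higher number from compound 3 to compound 4 (0.33 log units; beyond the scatter), resting on the step of an at least 1.7-fold higher number from compound 1 to compound 2 (0.24 log units; that floor lies within the scatter). The estimate for compound 4 in this assay is 45000 nM, with a range from 25000 nM to 120000 nM, and a substantial chance that only a limit is reported.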

Compound 4, half-maximal inhibitory concentration: > 50000 nM
Compound 4 was reported as a limit (the forecaster's own chance of this, stated with the estimate: 55%); middle value at least 1.1-fold (0.04 log units) from the limit.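

On the core of compound 3, trifluoromethyl in place of chloro gives an at least 2.3-fold higher number from compound 3 to compound 4 (0.37 log units; beyond the scatter) in this assay, and the result for compound 4 is a limit, not a number. The change points the same way on both cores shown, toward a higher number, but this does not fix its size on either core or show that the two sizes match: the same change on two cores in this assay, an at least 1.7-fold higher number (0.24 log units; that floor lies within the scatter) from compound 1 to compound 2 and an at least 2.3-fold higher number (0.37 log units; beyond the scatter) from compound 3 to compound 4; the limit leaves it open whether they differ. The methoxy in place of hydrogen step from compound 2 to compound 4 cannot be read, with a limit at both ends: the limit of > 50000 nM in this assay, at which 2 of the 4 values shown sit.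

Still open, from the compounds shown here alone, is how large the trifluoromethyl step really is on either core, which only a measured number for compound 2 or compound 4 could settle. Also open, going by these compounds, is whether another group at the same place, such as an amine or a carboxylic acid, would give a number clearly different from that of compound 3 at 20900 nM.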